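Swapping isopropoxy for chloro in compound 1

The compounds below may be only part of what the source reports. "The series", "measured", "known", "first", "only" and "open" are said of these compounds alone.

Compound 1 `COc1ccc(C2=C(c3cc(OC)c(OC)c(OC)c3)C(=O)C(OC(C)=O)C2)cc1OC(C)C` was tested in an ADME assay on DU-145 cells (Homo sapiens) for cytotoxicity, read by MTT assay, with a stated time of 72 h; a higher number here means a weaker inhibitor, a lower number a stronger inhibitor. In this assay compound 1 gives > 100 ug/mL, which is a limit of the assay and not a number. Compound 2 `COc1cc(C2=C(c3cc(C)c(OC)c(C)c3)C(O)CC2=O)cc(OC)c1OC` gives > 100 ug/mL, again a limit. Together they make up (the limit of > 100 ug/mL in this assay, at which 2 of the 3 values shown sit), so compound 1 stands among the compounds without a measured number. Compound 3 `COc1ccc(C2=C(c3cc(OC)c(OC)c(OC)c3)C(=O)C(O[SiH2]C(C)(C)C)C2)cc1OC(C)C` gives a true number, 6.3 ug/mL.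

Compound 4 `COc1ccc(C2=C(c3cc(OC)c(OC)c(OC)c3)C(=O)C(OC(C)=O)C2)cc1Cl` changes compound 1 in a different place: chloro in place of isopropoxy on an aromatic carbon. In words, chloro replaces isopropoxy on an aromatic carbon.

Among the measured compounds shown here, the only measured step from compound 1 is an at least 15-fold lower number from compound 1 to compound 3 (1.20 log units; beyond the scatter). That step changes the group on an oxygen on a saturated carbon, and compound 4 keeps the group of compound 1 there. For the measured compounds named here, no measured step changes the isopropoxy group, so the large step to compound 3 bears on this change only weakly. A step of that size is therefore not expected, and a further reading at the limit is quite possible. The expected outcome is an at least 1.4-fold lower number from compound 1 to compound 4 (0.15 log units; that floor lies within the scatter), a small move toward a lower number at most. For compound 4 the estimate is 70 ug/mL, with an expected range from 20 ug/mL to 150 ug/mL.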

Compound 4, half-maximal inhibitory concentration: 64 ug/mL
Beside the measured number, compound 4's estimate is 1.1-fold (0.04 log units) above it; the measured number falls inside the stated range.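

In this assay compound 1 gives > 100 ug/mL, which is a limit of the assay and not a number, and it shares that reading with one other compound: the limit of > 100 ug/mL in this assay, at which 2 of the 4 values shown sit.

Chloro in place of isopropoxy on an aromatic carbon gives the first reading for a change at this position, an at least 1.5-fold lower number from compound 1 to compound 4 (0.19 log units; that floor lies within the scatter), and compound 4 has a true number where compound 1 has only a limit. From the compounds shown here alone, this shows that the aromatic position can be changed and the reading can come off the limit, while the group on the oxygen on a saturated carbon stays as it is in compound 1, but the real size of the step remains unknown and its floor alone gives no evidence of a real gain.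

Going by these compounds, only isopropoxy and chloro are seen on this aromatic carbon, so it stays open how an amine, a carboxylic acid or a longer chain there would read in this assay. On these data alone, it also stays open whether chloro on this carbon would read the same alongside the silicon-bearing group that compound 3 carries on the oxygen on a saturated carbon.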